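A Hexyl Chain Replaces Difluoromethyl on the Ether Oxygen

The source may report more compounds than this note shows. Statements on the series, on what has been measured and on what is new or still open speak of the compounds shown alone.

Going by the values given here, compound 3 `O=C1NCCN1c1ccc(S(=O)(=O)Nc2ccc(OC(F)F)cc2)cc1` stands apart in this small set: in a functional assay on HT-29 cells (Homo sapiens) for antiproliferative activity, read by sulforhodamine B assay, with a stated time of 48 h (on this read-out higher numbers stand for weaker inhibition and lower numbers for stronger inhibition), compound 3 gives 650 nM, the only plain number among the three measured compounds. Compound 1 `O=C1NCCN1c1ccc(S(=O)(=O)Nc2ccc(C3CCCCC3)cc2)cc1` carries a cyclohexyl group on an aromatic carbon where compound 3 carries difluoromethoxy. In this assay compound 1 reaches only the limit > 1000 nM. Compound 2 `CCCCCCCc1ccc(NS(=O)(=O)c2ccc(N3CCNC3=O)cc2)cc1` carries a heptyl chain on that aromatic carbon. In this assay compound 2 likewise stops at the limit > 1000 nM. Both of these sit at the limit of > 1000 nM in this assay, at which 2 of the 3 values shown sit, so the step that the two limits leave unreadable from compound 1 to compound 2 cannot be read. The steps of an at least 1.5-fold lower number from compound 1 to compound 3 (0.18 log units; that floor lies within the scatter) and an at least 1.5-fold lower number from compound 2 to compound 3 (0.18 log units; that floor lies within the scatter) both point the same way, toward the smaller difluoromethoxy group.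

Compound 4 `CCCCCCOc1ccc(NS(=O)(=O)c2ccc(N3CCNC3=O)cc2)cc1` keeps the oxygen on the aromatic ring of compound 3 but changes what hangs on it: hexyl in place of difluoromethyl on an oxygen on an aromatic ring. Read one bond further out, this is difluoromethoxy to hexyloxy, and the hexyl chain recalls the heptyl of compound 2. The step that bears most on it is an at least 1.5-fold lower number from compound 2 to compound 3 (0.18 log units; that floor lies within the scatter), which went from a limit to a number when a long chain gave way to difluoromethoxy; bringing a long chain back is expected to reverse that. The step of a 3.1-fold higher number from compound 3 to compound 4 (0.49 log units; beyond the scatter) is therefore expected to raise the number. Compound 4 is estimated at 2000 nM, within 600 nM to 7000 nM, with a fair chance that only a limit is reported.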

Compound 4, half-maximal inhibitory concentration: > 1000 nM
Compound 4: only a limit was reported (the forecaster's own chance of this, stated with the estimate: 55%); the middle value lies beyond the limit too.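

Keeping the oxygen on the aromatic ring does not by itself preserve a plain number: in this assay, putting hexyl in place of difluoromethyl gives an at least 1.5-fold higher number from compound 3 to compound 4 (0.18 log units; that floor lies within the scatter). As far as these compounds go, that figure is only a floor, so the true size of the change remains unknown, and the floor alone cannot be told apart from ordinary variation between repeated measurements. Compound 4 gives a limit and not a number, so its steps to compound 1 and compound 2 cannot be read, and the ether oxygen shows no visible advantage over a direct carbon link to the ring, with the set now gathering at one limit: the limit of > 1000 nM in this assay, at which 3 of the 4 values shown sit.

Among these four compounds, only difluoromethoxy gives a plain number, and they leave open whether that number goes with the fluorine atoms or with the short length of the group on the oxygen. Methoxy or ethoxy in the same place would help separate those two readings, and trifluoromethoxy would show what a further fluorine does.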